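The source may hold more compounds than are shown below. What is called first, only, known or untested is meant among the compounds shown, and "the series" means these compounds.

Measured compounds:
compound 1, `N#Cc1cccc(Cn2nc(-c3ccc(CO)o3)c3ccccc32)c1`, 26000 nM
compound 2, `OCc1ccc(-c2nn(Cc3ccccc3F)c3ncncc23)o1`, 9400 nM
compound 3, `Cc1nc(-c2nn(Cc3ccccc3F)c3ncccc23)oc1CO`, 900 nM

Of the compounds shown here, three have been tested in a functional assay (aorta) with Oryctolagus cuniculus as the target; on this read-out higher numbers stand for weaker inhibition and lower numbers for stronger inhibition. Compound 1 gives 26000 nM, compound 2 gives 9400 nM, and compound 3 gives 900 nM. On these numbers compound 3 stands lowest of the three; its nearest neighbour is compound 2, whose number is higher by a step beyond the scatter, and compound 1 lies further off still. No pair of these compounds differs in only one place, so no single step can be read from them directly; what can be said is that the two with a hydroxymethyl group on the five-membered ring give the two lower numbers.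

Compound 4, `Fc1ccccc1Cn1nc(-c2cc[nH]n2)c2cccnc21`, has not yet been measured. It is reached from compound 3 by one change: 1H-pyrazol-3-yl in place of 5-(hydroxymethyl)-4-methyl-1,3-oxazol-2-yl on an aromatic carbon. The hydrogen-bond donor is kept, but the hydroxymethyl group and two acceptors are lost.

The account expects a step upwards in this assay, to a higher number than compound 3, of a size beyond the scatter, a 5.6-fold higher number from compound 3 to compound 4 (0.74 log units; beyond the scatter). Compound 4 is estimated at 5000 nM, with a range from 1500 nM to 20000 nM.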

Compound 4, half-maximal inhibitory concentration: 1800 nM
Compound 4: middle estimate off by 2.8-fold (0.44 log units), on the high side; measured number inside the range.
By their numbers in this assay, from the lowest: compounds 3 and 4 (each within the scatter of the next); then compound 2; then compound 1.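

In this assay, going by these compounds alone, the step at this position, 1H-pyrazol-3-yl in place of 5-(hydroxymethyl)-4-methyl-1,3-oxazol-2-yl on an aromatic carbon of the shared core, comes to a 2.0-fold higher number from compound 3 to compound 4 (0.30 log units; within the scatter) and is the first single change that can be read. It shows that, on this core, the hydroxymethyl group, the methyl group and the oxazole ring can all leave together without a difference that stands out from the scatter, even though the entering group has 5 heavy atoms against 8 and 1 hydrogen-bond acceptor against 3, while the 1 hydrogen-bond donor is kept in the count. Nothing shown here accounts for how closely the two numbers agree.

Open, on these data alone, is how this position responds to a ring that carries no hydrogen-bond donor, such as plain phenyl or furan-2-yl, or to a substituted pyrazole, a carboxylic acid, an aminomethyl group or a longer chain such as 2-hydroxyethyl. Also open, as far as these compounds go, is whether 1H-pyrazol-3-yl would give a similar result on the cores of compound 1 and compound 2, which differ from compound 4 in more than one place.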